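Trifluoromethyl in Place of Chloro on the Aryl Ring

A few compounds are considered here, and "the series" means these few. Any claim that something is new, unique, unknown or untested is made for them only; others in the source may bear on it.

Measured compounds:
- compound 1, `COc1ccc(-n2nc(-c3ccccc3)nc2CNc2ccc(C(=O)NO)cc2)cc1`: 63.4%
- compound 2, `O=C(NO)c1ccc(NCc2nc(-c3ccccc3)nn2-c2ccc(Cl)cc2)cc1`: 55.4%

Of the compounds shown here, two have been measured in an assay on Sf9 cells for inhibition of protein deacetylase HDAC6 (Homo sapiens), read by fluorescence, with a stated time of 40 min, tested at 100 nM; on this read-out higher numbers stand for more inhibition at the one concentration tested (going by the name of the read-out) and lower numbers for less inhibition. Compound 1 gives 63.4%, and compound 2 gives 55.4%. For the measured compounds named here, on these two numbers compound 2 stands lowest, but its only neighbour is compound 1, and the step of a number 8 percentage points lower from compound 1 to compound 2 (within the scatter) lies within the scatter, so the two compounds cannot be told apart.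

Compound 3, `O=C(NO)c1ccc(NCc2nc(-c3ccccc3)nn2-c2ccc(C(F)(F)F)cc2)cc1`, has not yet been measured. It differs from compound 2 in one place: trifluoromethyl in place of chloro on an aromatic carbon.

Going by the values given here, only one measured step bears on this change. It is a number 8 percentage points lower from compound 1 to compound 2 (within the scatter), which swaps one small group for another on the same aromatic carbon that compound 3 now alters, and it stayed within the scatter. A second exchange at that position is therefore expected to give no step beyond the scatter in this assay , in either direction. The estimated step is a number 0.6 percentage points higher from compound 2 to compound 3 (within the scatter).

For compound 3 the estimated inhibition is 56%, with a range from 40% to 72%.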

Compound 3, a percentage reported as inhibition, at one concentration (the size of the read-out at that concentration, not a potency): 38.9%
Compound 3: middle estimate off by 17.1 percentage points, on the high side, outside the stated range (below it).
By their numbers in this assay, from the lowest: compound 3; then compounds 2 and 1 (each within the scatter of the next).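

Swapping chloro for trifluoromethyl brings a number 16.5 percentage points lower from compound 2 to compound 3 (beyond the scatter), and swapping methoxy for trifluoromethyl brings a number 24.5 percentage points lower from compound 1 to compound 3 (beyond the scatter), both read in this assay. The group at this position, para to a large group, therefore does make a difference: methoxy and chloro could not be told apart, whereas trifluoromethyl, with 4 heavy atoms where chloro has 1, leaves compound 3 with the lowest number of the three compounds. Nothing at hand speaks to the reason for this drop.

With only three groups shown at this aromatic carbon, it stays open whether the drop follows the number of heavy atoms in the group or is particular to trifluoromethyl, and a reading at one concentration gives the size of the inhibition, not a potency. A methyl group, an amine or a carboxylic acid at the same place, on the same core, would help show whether compound 3 is a lone case or part of a wider pattern.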